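This account rests on a few compounds, and the source may have more. Where it says the series, first, only, none or still open, it means among the compounds named here.

Three measured compounds and one unmeasured share a single core. Compound 1 `NS(=O)(=O)c1ccc2nc(-n3nc(C(F)(F)F)cc3-c3ccc(Br)cc3)sc2c1` gives 56% in a functional assay on the whole organism (strain Wistar albino) for inhibition, with Rattus norvegicus as the target, read by paw edema, with stated times of 30 min and 2 h, at a dose of 50 mg/kg by the oral route; on this read-out higher numbers stand for more inhibition at the one dose given (going by the name of the read-out) and lower numbers for less inhibition. Compound 2 `NS(=O)(=O)c1ccc2nc(-n3nc(C(F)(F)F)cc3-c3ccc(Cl)cc3)sc2c1` gives 42% in this assay. Compound 3 `NS(=O)(=O)c1ccc2nc(-n3nc(C(F)(F)F)cc3-c3ccco3)sc2c1` gives 46% in this assay; its steps to both other compounds lie within the scatter, a number 10 percentage points lower from compound 1 to compound 3 (within the scatter) and a number 4 percentage points higher from compound 2 to compound 3 (within the scatter). Compound 4 `NS(=O)(=O)c1ccc2nc(-n3nc(C(F)(F)F)cc3-c3ccc(F)cc3)sc2c1` differs from compound 3 by 4-fluorophenyl in place of furan-2-yl on an aromatic carbon. Among the measured compounds shown here, the steps that bear on this are the two aryl exchanges into compound 3, both within the scatter, and the halogen exchange a number 14 percentage points lower from compound 1 to compound 2 (beyond the scatter), which was modest. A return from furan-2-yl to a halophenyl is therefore expected to give no step beyond the scatter, a number 2 percentage points lower from compound 3 to compound 4 (within the scatter). Compound 4 is estimated at 44%, with a range from 30% to 58%.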

Compound 4, a percentage reported as inhibition, in the whole organism at one dose (the size of the read-out at that dose, not a potency): 48%
The estimate for compound 4 lay 4 percentage points below the measured number, and the stated range covers the measured number.
By their numbers in this assay, from the lowest: compounds 2, 3, 4 and 1 (each within the scatter of the next, the first and the last beyond it).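

Fluoro sits with both other halogens in this assay: the printed steps are a number 6 percentage points higher from compound 2 to compound 4 (within the scatter) and a number 8 percentage points lower from compound 1 to compound 4 (within the scatter) and both stay within the scatter, so bromo to chloro remains the only halogen exchange here that goes beyond it. Exchanging the five-membered oxygen ring for a fluorinated six-membered carbon ring gives a number 2 percentage points higher from compound 3 to compound 4 (within the scatter) and so separates 4-fluorophenyl from furan-2-yl at this position by no more than the scatter. No measurement at hand accounts for these readings.

Open, as far as these compounds go, is whether a different kind of group at this position, such as an amine or a carboxylic acid on the phenyl ring, would move the number beyond the scatter.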